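From compound 2 to compound 4: one group exchanged

A few compounds are considered here, and "the series" means these few. Any claim that something is new, unique, unknown or untested is made for them only; others in the source may bear on it.

In a physicochemical assay for lipophilicity, at pH 7.4 (a higher number here means a more lipophilic compound, a lower number a more polar compound), compound 1 (`Cc1cc(C(=O)Nc2cccc(F)c2)nn1Cc1cc(Cl)ccc1OCc1ccccc1`) gives 2.8 and compound 2 (`Cc1cc(C(=O)Nc2ccc(F)cc2)nn1Cc1cc(Cl)ccc1OCc1ccccc1`) gives 3 while compound 3 (`Cc1cc(C(N)=O)nn1Cc1cc(Cl)ccc1OCC(C)C`) gives 3.1 on the same scale. Compound 2 lies within the scatter of both other compounds, so its place among the three carries little weight.

Compound 4 (`Cc1cc(NC(=O)C(C)C)nn1Cc1cc(Cl)ccc1OCc1ccccc1`) has not yet been measured. It departs from compound 2 in one place, where (isopropylcarbonyl)amino stands in place of (4-fluorophenyl)carbamoyl on an aromatic carbon ((isopropylcarbonyl)amino in place of (4-fluorophenyl)carbamoyl on an aromatic carbon).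

For the measured compounds named here, only one measured step connects close neighbours (a number 0.20 log units higher from compound 1 to compound 2 (within the scatter)). It exchanges 3-fluorophenyl for 4-fluorophenyl on an amide-type nitrogen and stays within the scatter, so it does not show what removing that group would do. Compound 3 also has no fluorophenyl group and differs in its ether as well, yet it gives 3.1 in this assay, which offers only indirect guidance.

A small downward move is therefore expected, hardly clear of the scatter, and the estimated step is (a number 0.20 log units lower from compound 2 to compound 4 (within the scatter)). Compound 4 is estimated at 2.8 in this assay with an expected range from 2.3 to 3.3 as its span.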

Compound 4, distribution coefficient: > 3.7
Compound 4 ended at the assay's limit (the forecaster's own chance of this, stated with the estimate: 2%); middle value at least 0.90 log units away from the limit.
By their numbers in this assay, from the lowest: compounds 1, 2 and 3 (each within the scatter of the next). At a limit, above all of these: compound 4.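

Putting (isopropylcarbonyl)amino in place of (4-fluorophenyl)carbamoyl on this aromatic carbon of the five-membered ring gives a number at least 0.70 log units higher from compound 2 to compound 4 (beyond the scatter) in this assay, the first step among these compounds to clear the scatter. The exchange against the other fluorophenyl isomer, with (isopropylcarbonyl)amino in place of (3-fluorophenyl)carbamoyl, gives a number at least 0.90 log units higher from compound 1 to compound 4 (beyond the scatter), so the position responds to this exchange with either isomer leaving, even though the entering group has fewer heavy atoms and no ring. Compound 4 gives > 3.7, which is a limit of the assay and not a number: the limit of > 3.7 in this assay, at which 1 of the 4 values shown sits.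

The exchange changes two things together, the direction of the amide link on the ring and the group carried at its far end, and the compounds shown do not separate these two changes. On these data alone, how far the read-out in this assay would move with isopropylcarbamoyl on this aromatic carbon, which would keep the link of compounds 1 and 2 while carrying the isopropyl group, remains open, as does the outcome with an amine or a carboxylic acid at the same place.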